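Replacing the side chain of compound 1 with (oxetan-2-yl)methyl

The compounds below may be only part of what the source reports. "The series", "measured", "known", "first", "only" and "open" are said of these compounds alone.

Measured in a functional assay on FaDu cells (Homo sapiens) for cytotoxicity, read by MTT assay, with a stated time of 72 h; a higher number here means that more compound is tolerated, a lower number that less compound is tolerated:
Compound 1 `COc1ccc(NC(=O)C(=O)c2cn(C(C)(C)COCC(=O)O)c3ccccc23)cn1` gives > 10000 nM, which is a limit
Compound 2 `COc1ccc(NC(=O)C(=O)c2cn(C(C)C)c3ncccc23)cn1` gives 126 nM
Compound 3 `COCCn1cc(C(=O)C(=O)Nc2ccc(OC)nc2)c2cccnc21` gives 27 nM

Compound 1 gives no number in this assay, only the limit > 10000 nM. Compound 4 `COc1ccc(NC(=O)C(=O)c2cn(CC3CCO3)c3ccccc23)cn1` keeps the core of compound 1 and differs only in the group on the aromatic nitrogen, where (oxetan-2-yl)methyl enters: a group of 5 heavy atoms (4 carbon, 1 oxygen; one four-membered non-aromatic ring with 1 hetero atom) in place of a group of 9 heavy atoms (6 carbon, 3 oxygen; no ring), on an aromatic nitrogen.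

Going by the values given here, no measured step starts from compound 1, and none uses its core. The nearest evidence is a 4.7-fold lower number from compound 2 to compound 3 (0.67 log units; beyond the scatter). That modest step, beyond the scatter, also changes a group on an aromatic nitrogen, but on the different core shared by compound 2 and compound 3. Compound 2 with isopropyl gives 126 nM and compound 3 with 2-methoxyethyl gives 27 nM. Among the compounds with values here, neither of these two groups resembles the one that leaves compound 1, so a large step to a lower number is expected, well beyond the scatter, though the change of core leaves its size uncertain. The expected change is an at least 120-fold lower number from compound 1 to compound 4 (2.09 log units; beyond the scatter). For compound 4 the estimated value is 80 nM, with an expected range from 15 nM to 500 nM.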

Compound 4, concentration lethal to 50% of the cells: 686 nM
The estimate for compound 4 lay 8.6-fold (0.93 log units) below the measured number; measured number above the stated range.
By their numbers in this assay, from the lowest: compound 3; then compound 2; then compound 4. At a limit, above all of these: compound 1.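

In this assay, (oxetan-2-yl)methyl on the aromatic nitrogen in place of the open chain of compound 1 gives an at least 14-fold lower number from compound 1 to compound 4 (1.16 log units; beyond the scatter), so the group at this position also matters on the core of compound 1, and not only on the core shared by compound 2 and compound 3. Going by these compounds alone, compound 4 also provides the first actual number on the core of compound 1, although the exchange alters several things at once: the ring, the count of heavy atoms, the double bond and the hydrogen-bond donor all differ, and this single step cannot separate them. The true size of the step stays unknown, as only its lower bound can be read: the limit of > 10000 nM in this assay, at which 1 of the 4 values shown sits.

The compounds shown leave open whether a carboxylic acid on a shorter chain at this nitrogen would behave like compound 1, and whether 2-methoxyethyl, an open chain without the acid, would give a number close to that of compound 4 on this core. They also leave open how an amine or a five-membered oxolane ring would read at this position.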